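Trading a Benzyloxy Arm for a Methoxypropoxy Chain

The source may report more compounds than this note shows. Statements on the series, on what has been measured and on what is new or still open speak of the compounds shown alone.

Of the compounds shown here, three have been measured in a physicochemical assay for lipophilicity, using the shake flask method; a lower number here means a more polar compound, a higher number a more lipophilic compound. Compound 3 `Nc1ncnc(Oc2ccc(NC(=O)C3(C(=O)Nc4ccc(F)cc4)CC3)cc2F)c1/C=N/OCc1ccccc1` gives 4.45, the highest of the three. Compound 1 `CCO/N=C/c1c(N)ncnc1Oc1ccc(NC(=O)C2(C(=O)Nc3ccc(F)cc3)CC2)cc1F` gives 3.41, and compound 2 `N/N=C/c1c(N)ncnc1Oc1ccc(NC(=O)C2(C(=O)Nc3ccc(F)cc3)CC2)cc1F` gives 2.25. Every step between them lies beyond the scatter: a number 1.04 log units higher from compound 1 to compound 3 (beyond the scatter), a number 1.16 log units lower from compound 1 to compound 2 (beyond the scatter), and a number 2.20 log units higher from compound 2 to compound 3 (beyond the scatter).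

Compound 4 `COCCCO/N=C/c1c(N)ncnc1Oc1ccc(NC(=O)C2(C(=O)Nc3ccc(F)cc3)CC2)cc1F` differs from compound 3 in one place: 2-methoxyethyl in place of phenyl on a saturated chain carbon bound to an oxygen. The step from compound 1 to compound 3 bears most directly on this, because a number 1.04 log units higher from compound 1 to compound 3 (beyond the scatter) shows what the phenyl contributed when it replaced a methyl. Removing that phenyl should undo much of that gain, and the entering 2-methoxyethyl brings one hydrogen-bond acceptor with it. A large downward step is therefore expected, a number 1.05 log units lower from compound 3 to compound 4 (beyond the scatter), so compound 4 is estimated at 3.4, within a range of 2.9 to 3.9.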

Compound 4, partition coefficient: 3.18
Beside the measured number, compound 4's estimate is 0.22 log units above it; low and high end bracket the measured number.
By their numbers in this assay, from the lowest: compound 2; then compounds 4 and 1 (each within the scatter of the next); then compound 3.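

Replacing the phenyl with 2-methoxyethyl takes the number down sharply in this assay (a number 1.27 log units lower from compound 3 to compound 4 (beyond the scatter)), yet the result still stands clear of the amino compound (a number 0.93 log units higher from compound 2 to compound 4 (beyond the scatter)). Methoxymethyl in place of hydrogen on the chain leaves compound 1 and compound 4 indistinguishable (a number 0.23 log units lower from compound 1 to compound 4 (within the scatter)), so here a longer chain carrying an oxygen reads like the short ethoxy. No measurement offered here explains these steps.

From the compounds shown here alone, whether a plain propoxy chain without that oxygen would read the same stays open. So does the effect of a chain ending in an amine or a carboxylic acid.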